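Adding one carbon to the propyl amide chain

A few compounds are considered here, and "the series" means these few. Any claim that something is new, unique, unknown or untested is made for them only; others in the source may bear on it.

Measured so far in a physicochemical assay for lipophilicity; a higher number here means a more lipophilic compound, a lower number a more polar compound
compound 1 `CCCCOC(=O)c1ccc(S(N)(=O)=O)cc1` gives 2.34
compound 2 `CCCNC(=O)c1ccc(S(N)(=O)=O)cc1` gives 0.51

Compound 2 at 0.51 is the lower of the two numbers. Compound 3 `CCCCNC(=O)c1ccc(S(N)(=O)=O)cc1` differs from it by methyl in place of hydrogen on a saturated chain carbon, three bonds along the chain from an amide-type nitrogen (propyl to butyl). Among the compounds with values here, one measured step bears on this, a number 1.83 log units lower from compound 1 to compound 2 (beyond the scatter) for propylamino in place of butoxy on a carbonyl carbon, and it is large. Within the data shown here, that step changes more than chain length, so no measured step isolates the present change. The expected change is a number 0.49 log units higher from compound 2 to compound 3 (beyond the scatter) as an estimate, upward and well short of that large step. For compound 3 the estimated value is 1 with 0.65 to 1.4 as the expected range.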

Compound 3, partition coefficient: 1.05
The estimate for compound 3 lay 0.05 log units below the measured number; measured number inside the range.
By their numbers in this assay, from the lowest: compound 2; then compound 3; then compound 1.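

Propyl to butyl in this assay gives a number 0.54 log units higher from compound 2 to compound 3 (beyond the scatter) and is the first reading that isolates methyl in place of hydrogen on this saturated chain carbon, three bonds along the chain from an amide-type nitrogen. With butyl on both sides, butylamino in place of butoxy gives a number 1.29 log units lower from compound 1 to compound 3 (beyond the scatter) as a large step, now free of any change in chain length. Nothing available explains either step.

From the compounds shown here alone, whether a longer chain such as pentyl would continue upward remains open. So does the outcome with a terminal amine or carboxylic acid on this chain.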